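Swapping the side chain of compound 2

The source may hold more compounds than are shown below. What is called first, only, known or untested is meant among the compounds shown, and "the series" means these compounds.

Measured so far in a functional assay on HL-60 cells (Homo sapiens) for antiproliferative activity, read by MTT assay, with a stated time of 24 h (on this read-out higher numbers stand for weaker inhibition and lower numbers for stronger inhibition), are three compounds.
- Compound 1 `CNC(=O)c1ccccc1Oc1nc(Nc2ccc(C)cc2C)ncc1Br` gives 32300 nM
- Compound 2 `COc1cc(Nc2nccc(NCCCN)n2)cc(OC)c1OC` gives > 50000 nM as a limit, not a number
- Compound 3 `COc1cc(Nc2ncc(I)c(NCCCN)n2)cc(OC)c1OC` gives 43400 nM

Compound 2 stands only at a limit (the limit of > 50000 nM in this assay, at which 1 of the 3 values shown sits), so its true place on the scale is not known. Compound 4 `CCN(CC)CCNc1ccnc(Nc2cc(OC)c(OC)c(OC)c2)n1` has yet to be measured in this assay and differs from compound 2 in the side chain alone. The change is diethylamino in place of aminomethyl on a saturated chain carbon, two bonds along the chain from a nitrogen on an aromatic ring and it reads as diethylamino in place of aminomethyl on a saturated chain carbon, two bonds along the chain from a nitrogen on an aromatic ring. Cut one bond further out, 3-aminopropyl becomes 2-(diethylamino)ethyl.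

Going by the values given here, the one measured step from compound 2 is an at least 1.1-fold lower number from compound 2 to compound 3 (0.06 log units; that floor lies within the scatter) and it concerns iodo in place of hydrogen on an aromatic carbon, elsewhere in the structure. Among the compounds with values here, it bears on the new change only loosely, and no measured pair alters the chain. No step beyond the scatter is therefore expected, in either direction. The estimated step is an at least 1.2-fold lower number from compound 2 to compound 4 (0.09 log units; that floor lies within the scatter) and it is expected to stay within the scatter. Compound 4 is expected to give 40000 nM (estimated range 15000 nM to 60000 nM).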

Compound 4, half-maximal inhibitory concentration: > 50000 nM
Compound 4 ended at the assay's limit; the forecaster's own chance of this, stated with the estimate: 50%; middle value at least 1.2-fold (0.09 log units) from the limit.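

Compound 2 and compound 4 both sit at a limit rather than a number in this assay, so no step between them can be read: the limit of > 50000 nM in this assay, at which 2 of the 4 values shown sit.

The compounds shown leave open how 2-(diethylamino)ethyl compares with 3-aminopropyl in this assay, as the side chain of compound 4 has no readable effect here.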